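Compound 1 and a thiophene swap

This account rests on a few compounds, and the source may have more. Where it says the series, first, only, none or still open, it means among the compounds named here.

compound 1 `Cc1ccc(-c2nc3ccccn3c2Sc2ccccc2)cc1`: 67900 nM
compound 2 `Cc1ccc(-c2nc3ccc(C)cn3c2Sc2ccccc2)cc1`: 14600 nM
compound 3 `Clc1ccc2nc(-c3ccccc3)c(Sc3ccccc3)n2c1`: 15700 nM

In a functional assay on HepG2 cells (Homo sapiens) for inhibition, read by MTT assay, with a stated time of 48 h (on this read-out higher numbers stand for weaker inhibition and lower numbers for stronger inhibition), compound 1 has the highest number of the three and is thus the weakest inhibitor here. Compound 4 `c1ccc(Sc2c(-c3cccs3)nc3ccccn23)cc1` carries thiophen-2-yl in place of 4-methylphenyl on an aromatic carbon. For the measured compounds named here, no measured step makes this swap, so the evidence is thin. The nearest guide is a different change, methyl in place of hydrogen on an aromatic carbon, which gave a 4.7-fold lower number from compound 1 to compound 2 (0.67 log units; beyond the scatter). That modest step points downward, so a smaller step towards a lower number is expected in this assay. The estimated change is a 1.7-fold lower number from compound 1 to compound 4 (0.23 log units; within the scatter). For compound 4 the estimated value is 40000 nM, with an expected range of 14000 nM to 110000 nM.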

Compound 4, half-maximal inhibitory concentration: 17100 nM
Compound 4: middle estimate off by 2.3-fold (0.37 log units), on the high side; the range from low to high includes it.
By their numbers in this assay, from the lowest: compounds 2, 3 and 4 (each within the scatter of the next); then compound 1.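

This is the first step shown at the position that holds 4-methylphenyl in compound 1. In this assay, thiophen-2-yl there gives a 4.0-fold lower number from compound 1 to compound 4 (0.60 log units; beyond the scatter), so replacing the six-membered carbon ring with a five-membered ring containing sulfur does not raise the number. Nothing measured here explains the step.

Open, from the compounds shown here alone, is how a different group at this position, such as a pyridine ring or a carboxylic acid, would read. Also open, going by these compounds, is whether thiophen-2-yl would give a similar step in compound 2.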